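Swapping a Methyl for Fluorine on the Aryl Ring

The source may report more compounds than this note shows. Statements on the series, on what has been measured and on what is new or still open speak of the compounds shown alone.

For the measured compounds named here, compound 1 `Cc1[nH]cnc1CN1CCN(c2cccc(Cl)c2)C1=O` and compound 2 `Cc1cccc(N2CCN(Cc3nc[nH]c3C)C2=O)c1` share the same core and differ only in the single group on the six-membered aromatic ring. In a functional assay (Cavia porcellus) for antagonist activity at Serotonin 3 (5-HT3) receptor (Homo sapiens) (on this read-out higher numbers stand for weaker inhibition and lower numbers for stronger inhibition), compound 1 gives 12 nM, and in this assay compound 2 gives 45.7 nM. Going by the values given here, of the two numbers measured so far, compound 2 holds the higher one, and the only step available, a 3.8-fold higher number from compound 1 to compound 2 (0.58 log units; beyond the scatter), came from placing methyl where chloro had been.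

Compound 3 `Cc1[nH]cnc1CN1CCN(c2cccc(F)c2)C1=O` carries fluoro in place of methyl on an aromatic carbon. Among the compounds with values here, this change bears directly on the one measured step: it again removes the methyl and again puts a halogen in its place, only a smaller one than chloro. That step was modest but beyond the usual scatter, so a move back toward a lower number is expected here, of a size comparable to that step or a little smaller. For compound 3 the expected step is therefore a 2.3-fold lower number from compound 2 to compound 3 (0.36 log units; beyond the scatter). In this assay compound 3 is estimated to give 20 nM, with a likely range from 8 nM to 50 nM.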

Compound 3, antagonist equilibrium constant: 88.3 nM
Compound 3: middle estimate off by 4.4-fold (0.64 log units), on the low side; measured number outside the range, above it.
By their numbers in this assay, from the lowest: compound 1; then compounds 2 and 3 (each within the scatter of the next).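

At this place on the aromatic ring, the halogens do not behave as one family. In this assay, fluoro and methyl cannot be told apart (a 1.9-fold higher number from compound 2 to compound 3 (0.29 log units; within the scatter)), whereas replacing chloro with fluoro gives a clear change (a 7.4-fold higher number from compound 1 to compound 3 (0.87 log units; beyond the scatter)), so compound 1, with chloro, stands as the strongest inhibitor of the three. Nothing shown here explains why chloro differs from the other two groups.

From the compounds shown here alone, with only chloro, fluoro and methyl to compare, it remains open whether bromo, methoxy or trifluoromethyl at the same carbon would give a number close to that of compound 1 or one in the range of compounds 2 and 3. Also open, going by these compounds, is whether chloro would keep its standing on a different carbon of the same aromatic ring, or whether its advantage belongs only to the one place tested here.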